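A few compounds are considered here, and "the series" means these few. Any claim that something is new, unique, unknown or untested is made for them only; others in the source may bear on it.

Of the compounds shown here, two have been measured here. Compound 1 `Cc1nnc(SCC(=O)N/N=c2/scc(-c3ccc(Cl)cc3)n2-c2ccccc2)s1` gives in a functional assay on C6 cells (Rattus norvegicus) for cytotoxicity, read by MTT assay, with a stated time of 24 h, tested at 6 ug/mL (on this read-out lower numbers stand for a stronger effect and higher numbers for a weaker effect at the one concentration tested), a value of 82.8%. Compound 2 `Cc1ccc(-c2cs/c(=N/NC(=O)CSc3nnnn3C)n2-c2ccccc2)cc1` gives in this assay a value of 88%. On these two numbers compound 2 has the higher reading, though the gap to compound 1 lies within the usual scatter, so the two cannot be told apart, and both leave most of the cells alive at the concentration used.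

Compound 3 `Cc1ccc(-c2cs/c(=N/NC(=O)CSc3nnc(C)s3)n2-c2ccccc2)cc1` has not been measured yet. It differs from compound 2 in one place: 5-methyl-1,3,4-thiadiazol-2-yl in place of 1-methyl-1H-tetrazol-5-yl on a sulfur. Among the compounds with values here, no pair of measured compounds shows this exchange on its own, so its effect on the read-out is unknown. Compound 1 does carry the same entering group, but it also differs from compound 3 at the aromatic ring on the other side of the core, so its value can only hint that this group is compatible with a weak effect.

On that basis the expected step from compound 2 to compound 3 is a number 3 percentage points lower from compound 2 to compound 3 (within the scatter), no more than the scatter. Compound 3 is therefore estimated at 85% in this assay, within a range from 72% to 95%.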

Compound 3, a percentage reported as activity, at one concentration (the size of the read-out at that concentration, not a potency): 65.9%
The estimate for compound 3 lay 19.1 percentage points above the measured number; measured number below the stated range.
By their numbers in this assay, from the lowest: compound 3; then compounds 1 and 2 (each within the scatter of the next).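

Read alone, 5-methyl-1,3,4-thiadiazol-2-yl in place of 1-methyl-1H-tetrazol-5-yl on a sulfur gives a number 22.1 percentage points lower from compound 2 to compound 3 (beyond the scatter) in this assay and so shows that the ring carried on this sulfur can change the reading, here towards a stronger effect on the cells. Methyl in place of chloro on an aromatic carbon gives a number 16.9 percentage points lower from compound 1 to compound 3 (beyond the scatter) and so shows that the entering ring does not set the reading alone, since the group on the aromatic ring at the other side of the shared core also counts. No measurement at hand bears on why either exchange shifts the reading.

Going by these compounds, whether the two exchanges would act the same way in other combinations stays open, as does what other groups would do in place of that methyl or chloro on the aromatic carbon, such as a methoxy group or an amine, or an ethyl chain in place of the methyl on the 5-methyl-1,3,4-thiadiazol-2-yl ring. Each reading also comes from a single concentration, so the compounds shown give no potency and leave open how the effect changes with dose.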